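This account rests on a few compounds, and the source may have more. Where it says the series, first, only, none or still open, it means among the compounds named here.

Among the compounds with values here, compound 2 `O=C(O)c1ccnc(Nc2cc3[nH]c(-c4cccc(C(F)(F)F)c4)nc3cn2)c1` gives 60000 nM in a physicochemical assay for solubility, using the shake flask method, in simulated intestinal fluid, measured as kinetic solubility, with a stated time of 20 h, at pH 6.5 (on this read-out lower numbers stand for lower solubility and higher numbers for higher solubility), and this is the only plain number among the values shown. Compound 1 `Fc1ccc(Nc2cc3[nH]c(-c4cccc(C(F)(F)F)c4)nc3cn2)nc1` gives >= 50000 nM in this assay, which is a limit rather than a number (the limit of >= 50000 nM in this assay, at which 1 of the 2 values shown sits). As a result the step that the limit leaves unreadable from compound 1 to compound 2 cannot be read in size or direction. Compound 3 `NC(=O)c1ccc(Nc2cc3[nH]c(-c4cccc(C(F)(F)F)c4)nc3cn2)nc1` differs from compound 2 by 5-carbamoylpyridin-2-yl in place of 4-carboxypyridin-2-yl on a nitrogen on an aromatic ring. Within the data shown here, none of the measured steps bears on this change, so no shift beyond the usual scatter is expected. The step of a 1.5-fold lower number from compound 2 to compound 3 (0.18 log units; within the scatter) is expected to stay small. Compound 3 is therefore estimated at 40000 nM, with a range from 10000 nM to 100000 nM.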

Compound 3, solubility: < 5000 nM
Compound 3 ended at the assay's limit (the forecaster's own chance of this, stated with the estimate: 30%); middle value at least 8.0-fold (0.90 log units) away from the limit.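

On the nitrogen on an aromatic ring, the earlier pair gave no readable step, but 5-carbamoylpyridin-2-yl in place of 4-carboxypyridin-2-yl brings a large fall in this assay (an at least 12-fold lower number from compound 2 to compound 3 (1.07 log units; beyond the scatter)). Carbamoyl in place of fluoro on an aromatic carbon also lowers the number (an at least 10-fold lower number from compound 1 to compound 3 (1.00 log units; beyond the scatter)). As far as these compounds go, compound 3 gives a limit, not a number (< 5000 nM), so the full size of both steps stays unknown.

Still open, from the compounds shown here alone, is whether the fall follows the carbamoyl group or where it sits, which a 5-carboxypyridin-2-yl group would help separate. Going by these compounds, how an amine in that place would behave also stays open.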